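The source may hold more compounds than are shown below. What is called first, only, known or untested is meant among the compounds shown, and "the series" means these compounds.

Compound 1 `Cc1ccc(C(=O)/C=C/c2ccc3c(c2)B(O)OC3)cc1`: > 10 ug/mL
Compound 2 `O=C(/C=C/c1ccc2c(c1)B(O)OC2)c1ccccc1O`: > 10 ug/mL

In an ADME assay on L929 cells (Mus musculus) for cytotoxicity, read by resazurin assay, with a stated time of 72 h (a lower number here means a stronger inhibitor, a higher number a weaker inhibitor), compound 1 gives only > 10 ug/mL, a limit of the assay rather than a number. Compound 2 likewise gives > 10 ug/mL, also a limit. The step that the two limits leave unreadable from compound 1 to compound 2 therefore cannot be read; the two values sit together at the limit of > 10 ug/mL in this assay, at which 2 of the 2 values shown sit. Compound 3 `O=C(/C=C/c1ccc2c(c1)B(O)OC2)c1ccc([N+](=O)[O-])cc1` differs from compound 1 by nitro in place of methyl on an aromatic carbon. Going by the values given here, no measured step reads on this change, so the expectation rests on compound 1 alone. Compound 3 is expected at 10 ug/mL, between 5 ug/mL and 30 ug/mL, most likely again as a limit. Compound 3 is thus expected to show a number no higher from compound 1 to compound 3 (the limit leaves the size open), nothing beyond the scatter.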

Compound 3, half-maximal inhibitory concentration: > 10 ug/mL
Compound 3: a limit, no number (the forecaster's own chance of this, stated with the estimate: 75%); the middle value lies on the limit itself.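

The step from compound 1 to compound 3 cannot be read, as both values are limits and not numbers: the limit of > 10 ug/mL in this assay, at which 3 of the 3 values shown sit.

The compounds shown leave open whether nitro in place of methyl changes the result at all in this assay.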